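Ring-closing the amine on a shared core

The compounds below may be only part of what the source reports. "The series", "measured", "known", "first", "only" and "open" are said of these compounds alone.

Three compounds share one core and differ only in the group attached to the ring carbon next to the pyridine-type nitrogen. Compound 1 `CCCCN(C)c1nc(C(F)(F)F)ccc1CNC(=O)C(C)c1ccc(NS(C)(=O)=O)c(F)c1` gives 21.3 nM in a functional assay on CHO-K1 cells for antagonist activity at transient receptor potential cation channel subfamily V member 1 (Homo sapiens), read by FLIPR (on this read-out lower numbers stand for stronger inhibition and higher numbers for weaker inhibition), the lowest of the three numbers. Compound 2 `CC(C(=O)NCc1ccc(C(F)(F)F)nc1N1CCC(Cc2cc(F)cc(F)c2)CC1)c1ccc(NS(C)(=O)=O)c(F)c1` gives 24 nM, which sits within the scatter of compound 1. Compound 3 `CC(C(=O)NCc1ccc(C(F)(F)F)nc1N1CCC(OC(=O)C(C)(C)C)CC1)c1ccc(NS(C)(=O)=O)c(F)c1` gives 45.2 nM, beyond the scatter from compound 1. Among the measured compounds shown here, the one directly comparable step, a 1.9-fold higher number from compound 2 to compound 3 (0.27 log units; within the scatter), shows that swapping a substituent on the saturated ring at this position changes little.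

Compound 4 `CC(C(=O)NCc1ccc(C(F)(F)F)nc1N1CCCCCCC1)c1ccc(NS(C)(=O)=O)c(F)c1` carries the change (a group of 8 heavy atoms (7 carbon, 1 nitrogen; one eight-membered non-aromatic ring with 1 hetero atom) in place of a group of 6 heavy atoms (5 carbon, 1 nitrogen; no ring), on an aromatic carbon). The values of compound 1 and compound 2 show that an open chain and a saturated ring at this position give similar numbers, and the step from compound 2 to compound 3 stays within the scatter, so no step beyond the scatter is expected here. The expected step is a 1.2-fold higher number from compound 1 to compound 4 (0.07 log units; within the scatter). Compound 4 is estimated at 25 nM, with a range from 10 nM to 65 nM.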

Compound 4, half-maximal inhibitory concentration: 27.8 nM
Beside the measured number, compound 4's estimate is 1.1-fold (0.05 log units) below it, and the stated range covers the measured number.
By their numbers in this assay, from the lowest: compounds 1, 2, 4 and 3 (each within the scatter of the next, the first and the last beyond it).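

In this assay, exchanging the open butyl(methyl)amino group for an eight-membered non-aromatic ring gives a 1.3-fold higher number from compound 1 to compound 4 (0.12 log units; within the scatter), so the change in shape from chain to ring does not separate these two compounds. Compound 2 and compound 3 had shown rings only with a substituent, whereas compound 4 shows that a larger ring with no substituent also fits on this aromatic carbon next to the ring nitrogen. No measurement shown here explains why these numbers stay so close.

Going by these compounds, it remains open whether a much smaller amine, such as azetidine or dimethylamino, would keep the number in this range. The same question applies to a ring with a second hetero atom, such as morpholine or piperazine, at this position.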